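Lengthening the ether chain on a hydroxyacetophenone core

The source may report more compounds than this note shows. Statements on the series, on what has been measured and on what is new or still open speak of the compounds shown alone.

Of the compounds shown here, three sharing one core have been measured in an assay on isolated protein for inhibition of leukotriene B4 receptor 1 (Homo sapiens), tested at 10 uM; a higher number here means more inhibition at the concentration tested (going by the name of the read-out), a lower number less inhibition. Compound 1, `CCc1cc(C(C)=O)c(O)cc1OCCCCC#N`, carries a chain of five carbons ending in a nitrile on the aromatic oxygen, and in this assay compound 1 gives 92%. Compound 3, `CCc1cc(C(C)=O)c(O)cc1OCCCCCC(C)(C)c1nnn(C)n1`, carries a still longer chain ending in a methyltetrazole, and compound 3 gives 95%. Compound 2, `C=CCc1cc(C(C)=O)c(O)cc1OCC#N`, has only a cyanomethyl group on that oxygen, and compound 2 gives 20%, the lowest of the three numbers; its gap to compound 1 and its gap to compound 3 both lie beyond the scatter.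

Compound 4, `C=CCc1cc(C(C)=O)c(O)cc1OCCCCCC`, keeps the allyl group and the core of compound 2 but changes the ether substituent: pentyl in place of cyano on a saturated chain carbon bound to an oxygen on an aromatic ring. The result is a hexyl chain on the aromatic oxygen, comparable in length to the chain of compound 1.

Among the measured compounds shown here, no measured pair differs in exactly this way, so the expectation rests on the two long-chain compounds. An increase is expected from compound 2 to compound 4 of about a number 55 percentage points higher from compound 2 to compound 4 (beyond the scatter), because compound 1 gives 92% and compound 3 gives 95% while compound 2 gives 20%. Compound 4 is therefore estimated at 75%, with a range from 45% to 95%.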

Compound 4, a percentage reported as inhibition, at one concentration (the size of the read-out at that concentration, not a potency): 50%
Compound 4: middle estimate off by 25 percentage points, on the high side; the range from low to high includes it.
By their numbers in this assay, from the lowest: compound 2; then compound 4; then compounds 1 and 3 (each within the scatter of the next).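

With the allyl group and the shared core held fixed, putting pentyl in place of cyano on a saturated chain carbon bound to an oxygen on an aromatic ring gives, in this assay, a number 30 percentage points higher from compound 2 to compound 4 (beyond the scatter). Among the compounds shown here, this is the first comparison that isolates this position: compounds 1, 2 and 3 differ from one another in more than one place, so their numbers could not separate the ether substituent from the rest of the structure, whereas this step, which can also be read as cyanomethyl to hexyl, shows that the ether substituent alone moves the number by a modest amount that lies beyond the scatter. No measurement offered here bears on why the number moves with this change.

Compound 4 differs from compound 1 in more than one place, so the part played by ethyl as against allyl stays unresolved, and an ethyl group in place of the allyl group on compound 4 would be the direct test. Also open, from the compounds shown here alone, is how far the chain itself counts as against its end, which a hexyl chain ending in a nitrile or a carboxylic acid on the allyl core would address.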